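A few compounds are considered here, and "the series" means these few. Any claim that something is new, unique, unknown or untested is made for them only; others in the source may bear on it.

Compound 1 `CCOC(=O)CO/N=C(/c1ccc(OC)c(OC)c1OC)c1cccc2ccccc12` and compound 2 `CCOC(=O)/C=C/CO/N=C(/c1ccc(OC)c(OC)c1OC)c1cccc2ccccc12` are the two measured compounds.

In a functional assay on MCF7 cells (Homo sapiens) for inhibition, read by sulforhodamine B assay, with a stated time of 48 h (a lower number here means a stronger inhibitor, a higher number a weaker inhibitor), compound 1 gives > 20000 nM, which is a limit of the assay. In this assay compound 2 gives > 20000 nM, also a limit. Compound 2 therefore stands at the limit, where both values sit (the limit of > 20000 nM in this assay, at which 2 of the 2 values shown sit). Among the compounds with values here, the only measured step, a step that the two limits leave unreadable from compound 1 to compound 2, cannot be read between two limits. Compound 3 `COc1ccc(/C(=N/OCC(=O)O)c2cccc3ccccc23)c(OC)c1OC` differs from compound 2 by carboxy in place of 2-(ethoxycarbonyl)ethenyl on a saturated chain carbon bound to an oxygen on an unsaturated carbon. Within the data shown here, no measured step bears on this change, so no direction can be read for it. Compound 3 is expected to remain at the limit, with an estimated value of 30000 nM and an expected range from 10000 nM to 100000 nM. The step that the limit leaves unreadable from compound 2 to compound 3 this estimate implies is expected to be none beyond the scatter.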

Compound 3, half-maximal inhibitory concentration: > 20000 nM
Compound 3 was reported as a limit (the forecaster's own chance of this, stated with the estimate: 85%); the middle value is on the limit's open side.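

In this assay compound 3 gives > 20000 nM, a limit, and no step among compound 1, compound 2 and compound 3 can be read: the limit of > 20000 nM in this assay, at which 3 of the 3 values shown sit.

The compounds shown leave open whether any of these changes alters inhibition in this assay.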